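This account rests on a few compounds, and the source may have more. Where it says the series, first, only, none or still open, it means among the compounds named here.

Working notes on the series. Compound 2 `Cc1noc(NS(=O)(=O)c2cccc3c(N4CCCCC4=O)cccc23)c1C` gives 270 nM in an assay on VSM-A10 cells for antagonist activity at Endothelin-1 receptor (Rattus norvegicus); a lower number here means a stronger inhibitor, a higher number a weaker inhibitor. Compound 1 `CCCNc1ccc(S(=O)(=O)Nc2onc(C)c2C)cc1` gives 27000 nM in this assay, and compound 3 `Cc1noc(NS(=O)(=O)c2cccc3c(N(C)C)cccc23)c1Cc1ccccc1` gives 50000 nM in this assay. Compound 2 therefore stands lowest of the three numbers; its nearest neighbour, compound 1, lies beyond the scatter above it, and compound 3 lies further still, so compound 2 is the most potent of the three measured compounds.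

Compound 4 `Cc1noc(NS(=O)(=O)c2cccc3ccccc23)c1C` has not yet been measured. It differs from compound 2 in one place: hydrogen in place of 2-oxopiperidin-1-yl on an aromatic carbon. For the measured compounds named here, no step between two measured compounds isolates this change, so nothing in the measured set shows directly what removing the group does. The expectation is a weakening step, beyond the scatter but of moderate size, with wide uncertainty in both directions. Compound 4 is expected to give about 1500 nM in this assay, with a range from 300 nM to 8000 nM. The expected step is a 5.6-fold higher number from compound 2 to compound 4 (0.74 log units; beyond the scatter).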

Compound 4, half-maximal inhibitory concentration: 20000 nM
Beside the measured number, compound 4's estimate is 13-fold (1.12 log units) below it; measured number outside the range, above it.
By their numbers in this assay, from the lowest: compound 2; then compounds 4, 1 and 3 (each within the scatter of the next, the first and the last beyond it).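

In this assay, for the compounds shown here, hydrogen in place of 2-oxopiperidin-1-yl on this aromatic carbon gives a 74-fold higher number from compound 2 to compound 4 (1.87 log units; beyond the scatter) and is the first measured step that isolates this position. The step is large, so the number of compound 2 depends strongly on this group, and the core of compound 4, with only hydrogen at this carbon, does not reach that level. No measurement shown accounts for the size of this step.

The compounds shown leave open which part of 2-oxopiperidin-1-yl matters, the ring or its carbonyl. A piperidine ring without the carbonyl and an open-chain acetamide on the same aromatic carbon would separate these two parts, and a methoxy group there would show whether a much smaller group recovers any of the step.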